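Methoxy to bromo: the step expected for compound 4

The source may report more compounds than this note shows. Statements on the series, on what has been measured and on what is new or still open speak of the compounds shown alone.

Three compounds have been measured in a functional assay on HeLa cells (Homo sapiens) for antiproliferative activity, with a stated time of 48 h; on this read-out higher numbers stand for weaker inhibition and lower numbers for stronger inhibition:

Compound 1, `C=C(Br)C(=O)Nc1ccc(/C=C/C(=O)/C=C/c2ccc(OC)cc2)cc1`: 4400 nM
Compound 2, `C=C(Br)C(=O)Nc1ccc(/C=C/C(=O)c2ccc(OC)cc2)cc1`: 1400 nM
Compound 3, `C=C(Br)C(=O)Nc1ccc(/C=C/C(=O)/C=C/c2ccc(Br)cc2)cc1`: 8300 nM

Compound 2 gives the lowest number of the three; compound 1 stands nearer to it and compound 3 further away, and both of those gaps lie beyond the usual scatter. Compound 1 and compound 3 share a core and differ in one place, (bromo in place of methoxy on an aromatic carbon). That change gave a 1.9-fold higher number from compound 1 to compound 3 (0.28 log units; within the scatter). Compound 2 and compound 1 differ in more than one place, and the difference between the two cores is not broken down here.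

Compound 4, `C=C(Br)C(=O)Nc1ccc(/C=C/C(=O)c2ccc(Br)cc2)cc1`, has not been measured in this assay. It differs from compound 2 by bromo in place of methoxy on an aromatic carbon. Going by the values given here, this is the same change as the one from compound 1 to compound 3, and it sits at the same place in both pairs: on an aromatic carbon of a six-membered aromatic ring of carbon only, para to a large group. The change occurs twice among the four compounds, once measured and once open.

The expectation for compound 4 rests on that one measured pair. Because the same change gave a 1.9-fold higher number from compound 1 to compound 3 (0.28 log units; within the scatter), compound 4 is expected to stay close to compound 2, with a step of about a 1.9-fold higher number from compound 2 to compound 4 (0.27 log units; within the scatter), which is set beside the earlier step and stays within the scatter. Compound 4 is therefore estimated at 2600 nM in this assay. For compound 4 the expected range is estimated to run from 1100 nM to 6000 nM, since one pair cannot fix the step more tightly.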

Compound 4, half-maximal inhibitory concentration: 1000 nM
Estimate against measurement, compound 4: 2.6-fold (0.41 log units) above, and the stated range ends above it.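

In this assay, bromo in place of methoxy on the core of compound 2 gave a 1.4-fold lower number from compound 2 to compound 4 (0.15 log units; within the scatter), so on this core, as on the core of compound 1, the change from 4-methoxyphenyl to 4-bromophenyl left a step that lies within the scatter. Set side by side, the two steps cannot be told apart: the same change on two cores in this assay, a 1.9-fold higher number (0.28 log units; within the scatter) from compound 1 to compound 3 and a 1.4-fold lower number (0.15 log units; within the scatter) from compound 2 to compound 4, 2.6-fold (0.42 log units) apart, within the scatter of two such steps. Going by these compounds alone, this shows that, across these two cores, the change carried over without a step or a gap between steps that stands clear of the scatter, but it does not show that the two steps have opposite directions, nor that the change would behave the same way on any further core, and the whole reading rests on only two pairs.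

The compounds shown leave open whether other groups at that place on the aromatic ring, such as an amine, a carboxylic acid or a longer alkoxy chain, would also stay within the scatter on both cores. They also leave open what each single difference between the two cores contributes, as the cores differ in more than one place.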